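Replacing the 4-phenylphenyl tail of compound 1

The compounds below may be only part of what the source reports. "The series", "measured", "known", "first", "only" and "open" are said of these compounds alone.

Among the measured compounds shown here, compound 1 `CC(C)[C@H](NC(=O)COc1cccc2ccccc12)C(=O)N[C@@H](CC(=O)O)C(=O)COc1ccc(-c2ccccc2)cc1` is the only member of this set with a number rather than a limit in a functional assay on Jurkat cells (Homo sapiens); a higher number here means a weaker inhibitor, a lower number a stronger inhibitor: in this assay compound 1 gives 87900 nM. Compound 2 `CC(C)[C@H](NC(=O)COc1cccc2ccccc12)C(=O)N[C@@H](CC(=O)O)C(=O)COc1ccccc1C(F)(F)F` reaches only a limit in this assay, giving > 100000 nM. Compound 3 `CC(C)[C@H](NC(=O)COc1cccc2ccccc12)C(=O)N[C@@H](CC(=O)O)C(=O)COc1ccc([N+](=O)[O-])cc1` likewise sits at a limit in this assay, giving > 100000 nM. Each of these is the limit of > 100000 nM in this assay, at which 2 of the 3 values shown sit. The step of an at least 1.1-fold higher number from compound 1 to compound 2 (0.05 log units; that floor lies within the scatter) and the step of an at least 1.1-fold higher number from compound 1 to compound 3 (0.05 log units; that floor lies within the scatter) therefore each show only a floor that lies within the scatter, and the step that the two limits leave unreadable from compound 2 to compound 3 cannot be read at all. Compound 4 `CC(C)[C@H](NC(=O)COc1cccc2ccccc12)C(=O)N[C@@H](CC(=O)O)C(=O)COc1ccc(F)c(F)c1F` differs from compound 1 by 2,3,4-trifluorophenyl in place of 4-phenylphenyl on an oxygen on a saturated carbon. For the measured compounds named here, the nearest measured step is the one from compound 1 to compound 2, where a smaller fluorinated aryl ether also took the place of the 4-phenylphenyl and the number rose to the limit. For compound 4 a step of a 1.7-fold higher number from compound 1 to compound 4 (0.23 log units; within the scatter) is therefore expected, most probably ending at the limit once more. The estimate for compound 4 in this assay is 150000 nM, within 50000 nM to 450000 nM.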

Compound 4, half-maximal inhibitory concentration: 35800 nM
Estimate against measurement, compound 4: 4.2-fold (0.62 log units) above, and the stated range ends above it.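

The change to 2,3,4-trifluorophenyl gives a 2.5-fold lower number from compound 1 to compound 4 (0.39 log units; beyond the scatter), which shows that in this assay a single six-membered aromatic ring at this place, on an oxygen on a saturated carbon, can do better than the two rings of 4-phenylphenyl. Having one ring is not enough by itself, for the ring's substituents separate the single-ring compounds, with an at least 2.7-fold lower number from compound 2 to compound 4 (0.44 log units; beyond the scatter) and an at least 2.7-fold lower number from compound 3 to compound 4 (0.44 log units; beyond the scatter). These last two steps are floors only, as the starting compound of each stands at a limit: the limit of > 100000 nM in this assay, at which 2 of the 4 values shown sit.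

As far as these compounds go, it remains open whether a 4-fluorophenyl or a 2,3-difluorophenyl group would keep this gain, and so whether all of the fluorines count. A pentafluorophenyl group would test whether further fluorines lower the number again.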